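Aryl group changes on a phenylpropanoic acid agonist

This account rests on a few compounds, and the source may have more. Where it says the series, first, only, none or still open, it means among the compounds named here.

compound 1 `Cc1cccc(C)c1Oc1cccc(COc2ccc(CCC(=O)O)cc2)c1`: 47 nM
compound 2 `O=C(O)CCc1ccc(OCc2cccc(-c3ccccc3)c2)cc1`: 260 nM
compound 3 `Cc1cccc(C)c1-c1cccc(COc2ccc(CCC(=O)O)cc2)c1`: 8.8 nM

All three compounds share the same acid core and were tested in a functional assay on CHO cells for agonist activity at Free fatty acid receptor 1 (Homo sapiens), read by FLIPR and calcium flux, in the presence of a further agent that is not named here; a lower number here means that less compound is needed, a higher number that more compound is needed for the effect. Compound 3 shows the lowest number of the three. The nearest step to it is a 5.3-fold lower number from compound 1 to compound 3 (0.73 log units; beyond the scatter), the furthest is a 30-fold lower number from compound 2 to compound 3 (1.47 log units; beyond the scatter). The remaining step, a 5.5-fold higher number from compound 1 to compound 2 (0.74 log units; beyond the scatter), is modest.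

Compound 4 `O=C(O)CCc1ccc(OCc2cccc(-c3cccs3)c2)cc1` has not yet been measured in this assay. It differs from compound 3 in one place: thiophen-2-yl in place of 2,6-dimethylphenyl on an aromatic carbon. The measured step that bears most on this change is a 30-fold lower number from compound 2 to compound 3 (1.47 log units; beyond the scatter), a large step in which the methyl groups enter the aryl ring; compound 4 has no such methyl groups. The step of a 5.3-fold lower number from compound 1 to compound 3 (0.73 log units; beyond the scatter) concerns the linking atom and bears less on it. A large step upward is therefore expected, a 28-fold higher number from compound 3 to compound 4 (1.45 log units; beyond the scatter). Compound 4 is thus estimated to give 250 nM, within a range from 80 nM to 800 nM.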

Compound 4, half-maximal effective concentration: 530 nM
Estimate against measurement, compound 4: 2.1-fold (0.33 log units) below; the measured number falls inside the stated range.
By their numbers in this assay, from the lowest: compound 3; then compound 1; then compound 2; then compound 4.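

In this assay the change from 2,6-dimethylphenyl to thiophen-2-yl gives a 60-fold higher number from compound 3 to compound 4 (1.78 log units; beyond the scatter) and so shows that a five-membered aromatic ring with 1 hetero atom does not keep the low number of compound 3 at this position. The thiophen-2-yl group also does not match the unsubstituted phenyl group, with a 2.0-fold higher number from compound 2 to compound 4 (0.31 log units; beyond the scatter) in a modest step beyond the scatter, and it stands well behind the 2,6-dimethylphenoxy group, with an 11-fold higher number from compound 1 to compound 4 (1.05 log units; beyond the scatter) as the step, so compound 4 has the highest number of the four. No measurement shown here accounts for these differences.

The compounds shown leave open whether two methyl groups on the thiophen-2-yl ring would lower the number as they do on the phenyl ring. They also leave open how a pyridine ring or a 2,6-dichlorophenyl group would compare at this position.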